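The compounds below may be only part of what the source reports. "The series", "measured", "known", "first", "only" and "open" are said of these compounds alone.

In a functional assay on MDA-MB-231 cells (Homo sapiens) for antiproliferative activity, read by MTT assay, with a stated time of 48 h (on this read-out higher numbers stand for weaker inhibition of growth and lower numbers for stronger inhibition of growth), compound 1 `COC(=O)N1N=C(c2cccc(O)c2)CC1c1cc(OC)c(OC)c(OC)c1` gives 740 nM, the lowest number in its small set. Compound 2 `CCOC(=O)N1N=C(c2cccc(O)c2)CC1c1cc(OC)c(OC)c(OC)c1` gives 4710 nM, and the step is a 6.4-fold higher number from compound 1 to compound 2 (0.80 log units; beyond the scatter). Compound 3 `COc1cc(C2CC(c3cccc(O)c3)=NN2C(=O)OCc2ccccc2)cc(OC)c1OC` reaches only a limit of the assay, > 10000 nM. The step to it is an at least 13-fold higher number from compound 1 to compound 3 (1.13 log units; beyond the scatter).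

Compound 4 `COC(=O)N1N=C(c2ccc(O)cc2)CC1c1cc(OC)c(OC)c(OC)c1` has 4-hydroxyphenyl in place of 3-hydroxyphenyl on a carbon with a double bond to nitrogen. Both measured steps lie at the methoxycarbonyl group, not at this place, so they only suggest how far this assay can move from compound 1. A modest rise is therefore expected, with the estimated step being a 2.7-fold higher number from compound 1 to compound 4 (0.43 log units; beyond the scatter). The estimate for compound 4 is 2000 nM, within an expected range of 450 nM to 9000 nM.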

Compound 4, concentration for 50% growth inhibition: 7150 nM
Estimate against measurement, compound 4: 3.6-fold (0.55 log units) below, and the stated range covers the measured number.
By their numbers in this assay, from the lowest: compound 1; then compounds 2 and 4 (each within the scatter of the next). At a limit, above all of these: compound 3.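

Exchanging 3-hydroxyphenyl for 4-hydroxyphenyl on the carbon with a double bond to nitrogen gives, in this assay, a 9.7-fold higher number from compound 1 to compound 4 (0.99 log units; beyond the scatter). This place therefore moves the read-out as well as the methoxycarbonyl group does, even though the two groups have the same atoms, joined differently. Nothing at hand accounts for this step.

The compounds shown leave open how an amine or a methoxy group in place of the hydroxy group would read in this assay. As far as these compounds go, it also remains open whether 4-hydroxyphenyl would give a step of like size alongside the ethoxycarbonyl group of compound 2.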